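The compounds below may be only part of what the source reports. "The series", "measured", "known", "first", "only" and "open" are said of these compounds alone.

Compound 3 `CC(C)(C)c1ccc(OCCCON2C(N)=NC(N)=NC23CCSCC3)cc1` gives 1 nM in a functional assay on MDA-MB-231 cells (Homo sapiens) for antiproliferative activity, read by MTT assay, with a stated time of 72 h (a higher number here means a weaker inhibitor, a lower number a stronger inhibitor), the lowest number among the three measured compounds. Compound 1 `NC1=NC2(CCSCC2)N(OCCCOc2ccc(Cl)cc2)C(N)=N1` gives 350 nM in this assay, and compound 2 `NC1=NC2(CCSCC2)N(OCCCOc2ccc(Br)cc2)C(N)=N1` gives 440 nM. The steps of a 350-fold lower number from compound 1 to compound 3 (2.54 log units; beyond the scatter) and a 440-fold lower number from compound 2 to compound 3 (2.64 log units; beyond the scatter) were both large, whereas a 1.3-fold higher number from compound 1 to compound 2 (0.10 log units; within the scatter). Compound 4 `COc1ccc(OCCCON2C(N)=NC(N)=NC23CCSCC3)cc1` differs from compound 3 in one place: methoxy in place of tert-butyl on an aromatic carbon. Among the compounds with values here, no measured step exchanges a tert-butyl group for a methoxy group, so the steps that bear on this change are the two from the halogenated compounds to compound 3, which showed that the group at this aromatic carbon can shift the number by a very large amount. With the tert-butyl group gone, the number is expected to rise back toward the values seen for compound 1 and compound 2, although the size of that rise is uncertain. The step of a 200-fold higher number from compound 3 to compound 4 (2.30 log units; beyond the scatter) is therefore expected. Compound 4 is estimated at 200 nM, with a range from 20 nM to 2000 nM.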

Compound 4, half-maximal inhibitory concentration: 350 nM
Beside the measured number, compound 4's estimate is 1.8-fold (0.24 log units) below it; the range from low to high includes it.
By their numbers in this assay, from the lowest: compound 3; then compounds 1, 4 and 2 (each within the scatter of the next).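

In this assay, methoxy on this aromatic carbon, para to a large group, does not retain the number seen with tert-butyl, giving a 350-fold higher number from compound 3 to compound 4 (2.54 log units; beyond the scatter). Methoxy instead falls level with the two halogens, with no change at the digits printed from compound 1 to compound 4 (within the scatter) and a 1.3-fold lower number from compound 2 to compound 4 (0.10 log units; within the scatter), so the three groups are not told apart here and, among these four compounds, only the tert-butyl compound stands apart. No measurement is available that accounts for this difference.

The compounds shown leave open whether isopropyl or cyclohexyl on this carbon would give a number close to that of compound 3, or whether an amine or a carboxylic acid there would instead join compounds 1, 2 and 4. They also leave open whether tert-butyl would keep its number with a longer chain linking the aromatic ring to the shared core.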